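Aryl variation on the triazole nitrogen: antiproliferative notes

The source may report more compounds than this note shows. Statements on the series, on what has been measured and on what is new or still open speak of the compounds shown alone.

Of the compounds shown here, two have been tested in a functional assay on HepG2 cells (Homo sapiens) for antiproliferative activity, read by MTT assay, with a stated time of 48 h; on this read-out higher numbers stand for weaker inhibition and lower numbers for stronger inhibition. Compound 1 `Cc1ccc(C)c(-n2nncc2CN2C(=O)C3(C(C#N)=C(N)Oc4c3c3nc5ccccc5nc3c3ccccc43)c3ccccc32)c1` returns only a limit of the assay, > 50000 nM, and no number. Compound 2 `Cc1cccc(-n2nncc2CN2C(=O)C3(C(C#N)=C(N)Oc4c(N)cc5nc6ccccc6nc5c43)c3ccccc32)c1` likewise returns only a limit, > 50000 nM. Among the measured compounds shown here, compound 2 therefore stands at the same limit as the other value shown, and nothing separates the two compounds on this read-out; this is the whole of the evidence, (the limit of > 50000 nM in this assay, at which 2 of the 2 values shown sit), and no measured step between them exists.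

Compound 3 `COc1ccc(OC)c(-n2nncc2CN2C(=O)C3(C(C#N)=C(N)Oc4c(N)cc5nc6ccccc6nc5c43)c3ccccc32)c1` follows compound 2 with one change: 2,5-dimethoxyphenyl in place of 3-methylphenyl on an aromatic nitrogen.

For the measured compounds named here, with both measured values sitting at the limit, no step is known that would tell how changes at this nitrogen move the read-out in this assay. The expectation for the step that the limit leaves unreadable from compound 2 to compound 3 is therefore none beyond the scatter, with the most likely outcome again a limit. Compound 3 is estimated at 60000 nM, with a range from 15000 nM to 250000 nM, and the measured result will decide.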

Compound 3, half-maximal inhibitory concentration: 45100 nM
Beside the measured number, compound 3's estimate is 1.3-fold (0.12 log units) above it; low and high end bracket the measured number.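

In this assay, compound 3 gives the only actual number among the compounds shown, 45100 nM, so this aromatic nitrogen of the triazole can carry an aryl group that registers inside the measurable range of the read-out. Replacing 3-methylphenyl with 2,5-dimethoxyphenyl at this position gives an at least 1.1-fold lower number from compound 2 to compound 3 (0.04 log units; that floor lies within the scatter); this is only a floor on the step, and it does not separate the two compounds beyond the usual scatter of repeated measurements. The new number is therefore a first fixed point at this position rather than evidence of a gain, and the other values remain limits: the limit of > 50000 nM in this assay, at which 2 of the 3 values shown sit.

On these data alone, the true size of the step stays open, and so does whether the change matters at all, with compound 2 known only as a limit. Also open, as far as these compounds go, is whether a single methoxy group, a halogen such as chlorine, or an amine on the same phenyl ring would give a number clearly separated from that of compound 3 in this assay.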